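This account rests on a few compounds, and the source may have more. Where it says the series, first, only, none or still open, it means among the compounds named here.

Compound 1 `COc1ccc(C[C@@H](O)/C=C/C=C/C(=O)NCc2ccccc2)cc1OC` was tested in a functional assay on HeLa cells (Homo sapiens) for antiproliferative activity, read by sulforhodamine B assay, with a stated time of 48 h (a lower number here means a stronger inhibitor, a higher number a weaker inhibitor), where compound 1 gives 12900 nM, the higher of the two numbers recorded; the nearest, compound 2 `COc1ccc(C[C@@H](O)/C=C/C=C/C(=O)NCc2cc(OC)c(OC)c(OC)c2)cc1OC`, gives 10700 nM in this assay, within the scatter of compound 1. Compound 3 `COc1ccc(C[C@@H](O)/C=C/C=C/C(=O)N2CCCCC2)cc1OC` carries piperidin-1-yl in place of benzylamino on a carbonyl carbon. Among the compounds with values here, no step between two measured compounds is known that resembles this change, so the step is expected to be small, toward a weaker inhibitor if any, though a move within the scatter is just as possible; the estimate is a 1.2-fold higher number from compound 1 to compound 3 (0.09 log units; within the scatter) in this assay. Compound 3 is therefore estimated at 16000 nM, with a range from 5000 nM to 50000 nM.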

Compound 3, half-maximal inhibitory concentration: 14100 nM
Compound 3: middle estimate off by 1.1-fold (0.05 log units), on the high side; the measured number falls inside the stated range.
By their numbers in this assay, from the lowest: compounds 2, 1 and 3 (each within the scatter of the next).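

Putting piperidin-1-yl in place of benzylamino on a carbonyl carbon gives a 1.1-fold higher number from compound 1 to compound 3 (0.04 log units; within the scatter) in this assay, so this first step at this position stays within the scatter. The aromatic ring and the hydrogen-bond donor that leave with benzylamino can therefore both be lost here without a change beyond the scatter. No measurement bearing on this result is available to explain it. Open, on these data alone, is how a carboxylic acid, morpholin-4-yl or phenethylamino would fare on the same carbonyl carbon.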